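Adding a second chloro to the fused ring of compound 2

The compounds below may be only part of what the source reports. "The series", "measured", "known", "first", "only" and "open" are said of these compounds alone.

Measured so far:
compound 1 `Cc1cc(C)c(CNC(=O)c2cccc(OC(C)C)c2Cl)c(=O)[nH]1`: 2
compound 2 `Cc1cc(C)c(CN2CCc3ccc(-c4c(C)noc4C)c(Cl)c3C2=O)c(=O)[nH]1`: 2.6

In a physicochemical assay for lipophilicity, at pH 7.4 (on this read-out higher numbers stand for higher lipophilicity and lower numbers for lower lipophilicity), compound 2 stands highest of the two numbers; its nearest neighbour is compound 1, a number lower by a gap that lies beyond the scatter. Within the data shown here, no single-point step between measured compounds is available.

Compound 3 `Cc1cc(C)c(CN2CCc3c(Cl)cc(-c4c(C)noc4C)c(Cl)c3C2=O)c(=O)[nH]1` differs from compound 2 by chloro in place of hydrogen on an aromatic carbon. Among the measured compounds shown here, with no measured step of this kind, the step of a number 0.50 log units higher from compound 2 to compound 3 (beyond the scatter) is expected to be upward, moderate, and beyond the scatter. Compound 3 is estimated at 3.1, in the range 2.7 to 3.6 in this assay.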

Compound 3, distribution coefficient: 3.1
For compound 3 middle estimate and measured number coincide at the digits printed, and the stated range covers the measured number.
By their numbers in this assay, from the lowest: compound 1; then compound 2; then compound 3.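

In this assay, among these compounds, chloro in place of hydrogen on this aromatic carbon, ortho to a fused ring and para to a chloro group, gives the first step that changes one place only: a number 0.50 log units higher from compound 2 to compound 3 (beyond the scatter). The position therefore accepts a second chloro with a rise in the read-out that lies beyond the scatter. No measurement at hand bears on the reason for this step. From the compounds shown here alone, how an amine or a carboxylic acid on this same carbon would move this assay stays open, and so does whether the chloro step holds on another core.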